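A few compounds are considered here, and "the series" means these few. Any claim that something is new, unique, unknown or untested is made for them only; others in the source may bear on it.

In a physicochemical assay for lipophilicity, at pH 7.4 (on this read-out higher numbers stand for higher lipophilicity and lower numbers for lower lipophilicity), compound 2 `O=C(Nc1ccc2[nH]ncc2n1)[C@H]1CCCN1C(=O)C1(c2ccc(F)cc2)CCC1` gives 4.1. That lies within the scatter of compound 3 `O=C(Nc1ccc2[nH]c(=O)[nH]c2c1)[C@H]1CCCN1C(=O)C1(c2cccc(Cl)c2)CCCC1` at 4.4, and clearly short of compound 1 `O=C(Nc1ccc2[nH]ccc2n1)[C@H]1CCCN1C(=O)C1(c2cccc(Cl)c2)CCCC1` at 5.9. Compound 4 `O=C(Nc1ccc2[nH]ncc2n1)[C@H]1CCCN1C(=O)C1(c2ccc(Cl)cc2)CCC1` differs from compound 2 in one place chloro in place of fluoro on an aromatic carbon, para to a large group. For the measured compounds named here, no measured step makes this exchange. Going by the values given here, the only measured step, a number 1.50 log units lower from compound 1 to compound 3 (beyond the scatter), swaps a whole two-ring group on an amide-type nitrogen, so it sets no size for a change of a single atom. A much smaller move, upward, is expected here, though this is a judgement with no direct measurement behind it. The estimated step is a number 0.50 log units higher from compound 2 to compound 4 (beyond the scatter). Compound 4 is expected at 4.6, with a range of 4.2 to 5.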

Compound 4, distribution coefficient: 4.7
Estimate against measurement, compound 4: 0.10 log units below; the range from low to high includes it.
By their numbers in this assay, from the lowest: compounds 2, 3 and 4 (each within the scatter of the next, the first and the last beyond it); then compound 1.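

Chloro in place of fluoro on an aromatic carbon, para to a large group, gives in this assay a number 0.60 log units higher from compound 2 to compound 4 (beyond the scatter) for the exchange of one atom. For the compounds shown here, the only earlier step swapped a whole two-ring group, so this is the first measured size for a change this small, and it already lies beyond the usual scatter. Nothing available explains why the number moves. Still open, as far as these compounds go, is where a methoxy or an amine at this same place would fall, and whether this exchange gives a similar step on the core of compound 1.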